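Methyl on the linker nitrogen in two core series

The source may report more compounds than this note shows. Statements on the series, on what has been measured and on what is new or still open speak of the compounds shown alone.

Measured so far:
compound 1 `CC(C)c1onc(-c2c(Cl)cccc2Cl)c1COc1ccc(N(C)C(=O)c2ccc(C(=O)O)cc2)c(C(F)(F)F)n1`: 101%
compound 2 `CC(C)c1onc(-c2c(Cl)cccc2Cl)c1COc1ccc(NC(=O)c2ccc(C(=O)O)cc2)c(C(F)(F)F)n1`: 109%
compound 3 `CC(Nc1ccc(C(=O)O)cc1)c1ccc(OCc2c(-c3c(Cl)cccc3Cl)noc2C2CC2)nc1C(F)(F)F`: 99%

In an assay on isolated protein for agonist activity at Bile acid receptor (Homo sapiens), read by FRET (a lower number here means a smaller maximal response, a higher number a larger maximal response), compound 1 gives 101%, compound 2 gives 109% and compound 3 gives 99%. Within the core of compound 2, the change methyl in place of hydrogen on an amide-type nitrogen gives a number 8 percentage points lower from compound 2 to compound 1 (within the scatter). Compound 4 `CC(c1ccc(OCc2c(-c3c(Cl)cccc3Cl)noc2C2CC2)nc1C(F)(F)F)N(C)c1ccc(C(=O)O)cc1` carries the same kind of change on the core of compound 3, (methyl in place of hydrogen on a nitrogen on an aromatic ring); the place differs, an amide-type nitrogen with a carbonyl carbon neighbour against a nitrogen on an aromatic ring with a saturated chain carbon neighbour. The difference between the two cores is not broken down here. From compound 3 to compound 4 a step of a number 3 percentage points lower from compound 3 to compound 4 (within the scatter) in this assay is expected, resting on a number 8 percentage points lower from compound 2 to compound 1 (within the scatter) for the same kind of change. Compound 4 is estimated at 96%, between 84% and 110%.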

Compound 4, largest response reached (reported as efficacy), in percent of the reference or control that the assay uses: 102%
The estimate for compound 4 lay 6 percentage points below the measured number; low and high end bracket the measured number.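

In this assay, methyl in place of hydrogen on a nitrogen on an aromatic ring gives a number 3 percentage points higher from compound 3 to compound 4 (within the scatter). Set beside the same kind of change on the amide-type nitrogen, this step does not differ from the earlier one: the same change on two cores in this assay, a number 8 percentage points lower (within the scatter) from compound 2 to compound 1 and a number 3 percentage points higher (within the scatter) from compound 3 to compound 4, 11 percentage points apart, within the scatter of two such steps. This shows that the maximal response stays within the scatter on both cores, but it rests on one pair per core, at two different kinds of nitrogen, and does not show that the steps would agree wherever a larger step occurs.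

Still open, going by these compounds, is whether an ethyl group or a longer chain on this nitrogen would leave the maximal response in the same place. Also open, on these data alone, is how an acetyl group there would read.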